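This account rests on a few compounds, and the source may have more. Where it says the series, first, only, none or still open, it means among the compounds named here.

Series notes. Compound 1 `O=C(O)CCc1ccc(NCC2COc3ccc(Cl)cc3O2)cc1F` and compound 2 `CC#C[C@@H](CC(=O)O)c1ccc(OC[C@H]2COc3ccc(F)cc3O2)cc1` share no single-point relation, so only their two numbers are set side by side here. In a functional assay on HEK293 cells for agonist activity at Free fatty acid receptor 1 (Homo sapiens), read by fluorescence and calcium flux, with a stated time of 10 min (on this read-out higher numbers stand for larger maximal responses and lower numbers for smaller maximal responses), compound 1 gives 69%. In this assay compound 2 gives 86%, the higher of the two numbers, and the gap to compound 1 lies beyond the usual scatter.

Compound 3 `CC#C[C@@H](CC(=O)O)c1ccc(OC[C@H]2COc3ccc(S(C)(=O)=O)cc3O2)cc1` is not yet measured. It departs from compound 2 in one place: methylsulfonyl in place of fluoro on an aromatic carbon. For the measured compounds named here, no measured pair shows this exchange, so there is no observed step to lean on; the expectation rests on the standing of compound 2 alone. The step from compound 2 to compound 3 is expected to be small, a number 2 percentage points lower from compound 2 to compound 3 (within the scatter), with no confident direction and likely within the scatter. For compound 3 the estimated value in this assay is 84%, with a range from 65% to 100%.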

Compound 3, largest response reached (Emax), in percent of the reference or control that the assay uses: 55%
Compound 3: middle estimate off by 29 percentage points, on the high side, outside the stated range (below it).
By their numbers in this assay, from the lowest: compound 3; then compound 1; then compound 2.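

At the aromatic carbon that lies meta to a fused ring and para to a fused ring, the group present matters for the maximal response in this assay, with a large step of a number 31 percentage points lower from compound 2 to compound 3 (beyond the scatter) on methylsulfonyl in place of fluoro. For the compounds shown here, this is the first single-place exchange that can be read, and it shows that this position does not tolerate every substituent with the response kept, even though the rest of compound 3 matches compound 2. Nothing at hand bears on the reason for this step.

As far as these compounds go, only fluoro and methylsulfonyl are compared at this carbon, so it remains open where a nitrile or a methoxy group would fall between them or beyond them. Also open, from the compounds shown here alone, is whether the same exchange would give a step of like size on the core of compound 1.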